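A few compounds are considered here, and "the series" means these few. Any claim that something is new, unique, unknown or untested is made for them only; others in the source may bear on it.

For the measured compounds named here, compound 1 `CCCC/N=C/c1cc2cc(C)ccc2[nH]c1=O` is one of three compounds measured in a functional assay, read by spectrophotometry, with a stated time of 5 min; a higher number here means a weaker inhibitor, a lower number a stronger inhibitor. In this assay compound 1 gives 379000 nM, the second highest of the three numbers. Compound 2 `Cc1ccc2[nH]c(=O)c(/C=N/Nc3ccccc3)cc2c1` gives 309000 nM, and compound 3 `Cc1ccc2[nH]c(=O)c(/C=N/CCO)cc2c1` gives 1480000 nM. The step of a 1.2-fold lower number from compound 1 to compound 2 (0.09 log units; within the scatter), an anilino in place of butyl on the double-bonded nitrogen, lies within the scatter. The step of a 3.9-fold higher number from compound 1 to compound 3 (0.59 log units; beyond the scatter), a hydroxy in place of ethyl on a saturated chain carbon two bonds along the chain from the double-bonded nitrogen, is modest. Compound 4 `CCCC/N=C/c1cc2ccccc2[nH]c1=O` has not yet been measured. It differs from compound 1 by hydrogen in place of methyl on an aromatic carbon. Going by the values given here, neither measured step touches this part of the shared core; both change only the group on the double-bonded nitrogen, so no measured step bears directly on this change. Without a direct guide, the expected step of a 1.2-fold higher number from compound 1 to compound 4 (0.07 log units; within the scatter) is small and not beyond the scatter. Compound 4 is estimated at 450000 nM, with a range from 150000 nM to 1400000 nM.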

Compound 4, half-maximal inhibitory concentration: 246000 nM
Beside the measured number, compound 4's estimate is 1.8-fold (0.26 log units) above it; the range from low to high includes it.
By their numbers in this assay, from the lowest: compounds 4, 2 and 1 (each within the scatter of the next); then compound 3.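

For the compounds shown here, compound 4 is the only compound here whose change touches the shared core rather than the group on the double-bonded nitrogen. In this assay, losing the methyl from the aromatic carbon gives a 1.5-fold lower number from compound 1 to compound 4 (0.19 log units; within the scatter) and so lies within the usual spread of repeat measurements. With butyl on the double-bonded nitrogen, methyl and hydrogen at this aromatic carbon therefore cannot be told apart by this assay and no separate measurement is available to explain this result.

The compounds shown leave open whether a larger or different group on this aromatic carbon, such as a chlorine atom, a methoxy group or an amine, would shift the number beyond the scatter. They also leave open whether methyl and hydrogen would remain indistinguishable here with anilino or 2-hydroxyethyl on the double-bonded nitrogen.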